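Stretching the Side Chain of Compound 2

The source may report more compounds than this note shows. Statements on the series, on what has been measured and on what is new or still open speak of the compounds shown alone.

In a functional assay on EOL1 cells (Homo sapiens) for inhibition, read by fluorescence, with a stated time of 72 h (on this read-out lower numbers stand for stronger inhibition of growth and higher numbers for weaker inhibition of growth), compound 2 `CC(C)=CCn1cnc2c(Nc3cccc(Cl)c3)nc(N[C@H]3CC[C@H](N)CC3)nc21` reads 80 nM and lies within the scatter of compound 1 `CC(C)CCn1cnc2c(Nc3ccc(Cl)cc3)nc(N[C@H]3CC[C@H](N)CC3)nc21` (90 nM) and of compound 3 `CCCCn1cnc2c(Nc3ccc(Cl)cc3)nc(N[C@H]3CC[C@H](N)CC3)nc21` (50 nM), so the three cannot be told apart. Compound 4 `CC(C)=CCC/C(C)=C/Cn1cnc2c(Nc3cccc(Cl)c3)nc(N[C@H]3CC[C@H](N)CC3)nc21` extends the 3-methylbut-2-en-1-yl chain of compound 2 to 3,7-dimethylocta-2,6-dien-1-yl (3-methylbut-2-en-1-yl in place of hydrogen on a saturated chain carbon bound to a double-bonded chain carbon). For the measured compounds named here, the one measured step on such a chain (a 1.8-fold lower number from compound 1 to compound 3 (0.26 log units; within the scatter)) stayed within the scatter, but it concerns a single methyl, and no measured compound carries a chain this long. A small rise in the number, not clearly beyond the scatter, is therefore expected in this assay with wide uncertainty. The expected step is a 1.5-fold higher number from compound 2 to compound 4 (0.18 log units; within the scatter) on this evidence. Compound 4 is estimated at 120 nM within a range of 40 nM to 400 nM for now.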

Compound 4, concentration for 50% growth inhibition: 590 nM
Compound 4: middle estimate off by 4.9-fold (0.69 log units), on the low side; measured number outside the range, above it.
By their numbers in this assay, from the lowest: compounds 3, 2 and 1 (each within the scatter of the next); then compound 4.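

At this position the chain does not tolerate every extension: in this assay, adding 3-methylbut-2-en-1-yl on a saturated chain carbon bound to a double-bonded chain carbon gives a 7.4-fold higher number from compound 2 to compound 4 (0.87 log units; beyond the scatter) and so weakens growth inhibition. The earlier step, a 1.8-fold lower number from compound 1 to compound 3 (0.26 log units; within the scatter), changed only a single methyl and gave no sign of a shift this size. Nothing available explains the rise.

Going by these compounds, whether chain length or the added double bond drives it stays open. A saturated 3,7-dimethyloctyl chain, or a chain ending in an amine, could separate the two.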